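The source may hold more compounds than are shown below. What is called first, only, known or untested is meant among the compounds shown, and "the series" means these compounds.

Measured so far in a functional assay on NCI-H460 cells (Homo sapiens) for inhibition; on this read-out higher numbers stand for weaker inhibition of growth and lower numbers for stronger inhibition of growth:
compound 1 `C=C1CC(Cn2cc(C)c(=O)[nH]c2=O)(c2ccc(-c3ccccc3)cc2)OC1=O` — 13800 nM
compound 2 `C=C1CC(Cn2ccc(=O)[nH]c2=O)(c2ccc(-c3ccccc3)cc2)OC1=O` — 10200 nM

Among the compounds with values here, compound 2 holds the lower of these two numbers, yet the gap to compound 1 is small: the only measured step, a 1.4-fold lower number from compound 1 to compound 2 (0.13 log units; within the scatter), lies within the scatter. Compound 3 `C=C1CC(Cn2ccc(=O)[nH]c2=O)(c2ccc(F)cc2)OC1=O` arises from compound 2 by fluoro in place of phenyl on an aromatic carbon. Within the data shown here, no measured step touches this kind of change, so the expectation rests on nothing firmer than the shared core. For compound 3 the estimate in this assay is 20000 nM, between 6000 nM and 70000 nM. That amounts to an expected step of a 2.0-fold higher number from compound 2 to compound 3 (0.29 log units; within the scatter), a modest drift toward a higher number, with a wide range of doubt.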

Compound 3, concentration for 50% growth inhibition: 13800 nM
The estimate for compound 3 lay 1.4-fold (0.16 log units) above the measured number; the range from low to high includes it.
By their numbers in this assay, from the lowest: compounds 2, 1 and 3 (each within the scatter of the next).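

In this assay, putting fluoro in place of phenyl on this aromatic carbon, para to a large group, gives a 1.4-fold higher number from compound 2 to compound 3 (0.13 log units; within the scatter) and so does not separate the two compounds. This position therefore tolerates the loss of a whole phenyl ring in this read-out, at least with this replacement, and that is something the earlier step on a different position could not show. No measured evidence here explains this result.

From the compounds shown here alone, whether an amine or a carboxylic acid on the same carbon would also stay within the scatter remains open.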